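The source may hold more compounds than are shown below. What is called first, only, known or untested is meant among the compounds shown, and "the series" means these compounds.

Of the compounds shown here, three sharing one core have been measured in a functional assay on HeLa cells (Homo sapiens) for inhibition, read by CCK-8 assay, with a stated time of 48 h; a lower number here means a stronger inhibitor, a higher number a weaker inhibitor. Compound 1 (`O=S(=O)(NCCNC(=S)Nc1cccc(Cl)c1)c1ccc(-c2ccccc2OCc2ccccc2)s1`) gives 8400 nM and compound 2 (`O=[N+]([O-])c1cccc(NC(=S)NCCNS(=O)(=O)c2ccc(-c3ccccc3OCc3ccccc3)s2)c1`) gives 12800 nM. Nitro in place of chloro produced a 1.5-fold higher number from compound 1 to compound 2 (0.18 log units; within the scatter). Compound 3 (`O=C(NCCNS(=O)(=O)c1ccc(-c2ccccc2OCc2ccccc2)s1)Nc1cc(Cl)cc(Cl)c1`) reads > 20000 nM, which is a limit of the assay and not a number. Compound 4 (`O=S(=O)(NCCNC(=S)Nc1ccc(Cl)cc1)c1ccc(-c2ccccc2OCc2ccccc2)s1`) differs from compound 3 by one change: a group of 10 heavy atoms (7 carbon, 1 nitrogen, 1 sulfur, 1 chlorine; one six-membered aromatic ring of carbon only) in place of a group of 11 heavy atoms (7 carbon, 1 nitrogen, 1 oxygen, 2 chlorine; one six-membered aromatic ring of carbon only), on an amine nitrogen. The entering group matches compound 1's group in its atom counts, so the closest guide is an at least 2.3-fold higher number from compound 1 to compound 3 (0.37 log units; beyond the scatter), with an at least 1.5-fold higher number from compound 2 to compound 3 (0.19 log units; that floor lies within the scatter) as weaker support. Reversing that change suggests a lower number, meaning a stronger inhibitor. The expected step is an at least 2.1-fold lower number from compound 3 to compound 4 (0.32 log units; beyond the scatter). Compound 4 is estimated at 9500 nM, with an expected range of 4500 nM to 20000 nM.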

Compound 4, half-maximal inhibitory concentration: 7000 nM
Estimate against measurement, compound 4: 1.4-fold (0.13 log units) above; the range from low to high includes it.
By their numbers in this assay, from the lowest: compounds 4, 1 and 2 (each within the scatter of the next). At a limit, above all of these: compound 3.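

On this amine nitrogen, a second group carrying sulfur and one chlorine again reads clearly apart from the (3,5-dichlorophenyl)carbamoyl group (an at least 2.8-fold lower number from compound 3 to compound 4 (0.45 log units; beyond the scatter)). Among the sulfur-bearing groups, 4-chlorophenyl cannot be separated from 3-chlorophenyl (a 1.2-fold lower number from compound 1 to compound 4 (0.08 log units; within the scatter)) or from 3-nitrophenyl (a 1.8-fold lower number from compound 2 to compound 4 (0.26 log units; within the scatter)), as both steps lie within the scatter. The reading of compound 3 is a limit and not a number: the limit of > 20000 nM in this assay, at which 1 of the 4 values shown sits.

Still open, from the compounds shown here alone, is how much of the step from compound 3 belongs to sulfur for oxygen and how much to the second chlorine. Also open, going by these compounds, is how an amine or a carboxylic acid on that aromatic ring would read.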